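The compounds below may be only part of what the source reports. "The series", "measured", "known", "first", "only" and "open" are said of these compounds alone.

Compound 1 `O=C(/C=C\Nc1ccc(Cl)cc1)c1cn(-c2ccccc2)nc1-c1ccccc1` gives 28400 nM in an ADME assay on HaCaT cells (Homo sapiens) for antiproliferative activity, read by MTT assay, with a stated time of 48 h; on this read-out higher numbers stand for weaker inhibition and lower numbers for stronger inhibition. Compound 2 `COc1cc(N/C=C\C(=O)c2cn(-c3ccccc3)nc2-c2ccccc2)cc(OC)c1OC` gives 36200 nM in this assay. Compound 3 `COc1ccc(-c2nn(-c3ccccc3)cc2C(=O)/C=C\Nc2ccc(Cl)cc2)cc1` gives 20900 nM in this assay.

Compound 3 carries the lowest of the three numbers, but its neighbours sit close: the step of a 1.4-fold lower number from compound 1 to compound 3 (0.13 log units; within the scatter) is within the scatter, and compound 2 stands only somewhat further off. Compound 4 `COc1ccc(-c2nn(-c3ccccc3)cc2C(=O)/C=C\Nc2cc(OC)c(OC)c(OC)c2)cc1` differs from compound 3 by 3,4,5-trimethoxyphenyl in place of 4-chlorophenyl on an amine nitrogen. Going by the values given here, no measured step covers this exact change; the same swap separates compound 1, with 28400 nM, from compound 2, with 36200 nM in this assay, and those two numbers lie near one another. Compound 4 is therefore expected to show a 1.2-fold higher number from compound 3 to compound 4 (0.09 log units; within the scatter), no shift beyond the scatter. Compound 4 is estimated at 26000 nM, within a range from 12000 nM to 55000 nM.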

Compound 4, half-maximal inhibitory concentration: > 50000 nM
Compound 4 gave a limit, no number; the forecaster's own chance of this, stated with the estimate: 5%; middle value at least 1.9-fold (0.28 log units) from the limit.
By their numbers in this assay, from the lowest: compounds 3, 1 and 2 (each within the scatter of the next). At a limit, above all of these: compound 4.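

Going by these compounds alone, with the methoxy present on the core, 3,4,5-trimethoxyphenyl in place of 4-chlorophenyl on an amine nitrogen gives an at least 2.3-fold higher number from compound 3 to compound 4 (0.37 log units; beyond the scatter), the only step here beyond the scatter, whereas compound 1 (28400 nM) and compound 2 (36200 nM), which carry the same swap, lie near one another. Methoxy in place of hydrogen on an aromatic carbon gives an at least 1.3-fold higher number from compound 2 to compound 4 (0.14 log units; that floor lies within the scatter) with the 3,4,5-trimethoxyphenyl group present. Compound 4 gives only a limit: the limit of > 50000 nM in this assay, at which 1 of the 4 values shown sits.

On these data alone, whether the methoxy change acts alike on both cores stays open: the same change on two cores in this assay, a 1.4-fold lower number (0.13 log units; within the scatter) from compound 1 to compound 3 and an at least 1.3-fold higher number (0.14 log units; that floor lies within the scatter) from compound 2 to compound 4; the limit leaves it open whether they differ. Also open, as far as these compounds go, is how an amine or a carboxylic acid on the phenyl ring at that nitrogen would read.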